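Chloro on the fused ring of compound 2

The source may hold more compounds than are shown below. What is called first, only, known or untested is meant among the compounds shown, and "the series" means these compounds.

Compound 1 `Clc1ccc(-c2noc(-c3cc4ccccc4[nH]3)n2)cc1` gives 13900 nM in a functional assay on COLO 320 cells (Homo sapiens) for antiproliferative activity, read by WST assay, with a stated time of 72 h; on this read-out lower numbers stand for stronger inhibition and higher numbers for weaker inhibition. Compound 2 `COc1ccc(-c2noc(-c3cc4ccccc4[nH]3)n2)cc1` gives 27700 nM in this assay, the highest of the two numbers, the nearest number being a 2.0-fold higher number from compound 1 to compound 2 (0.30 log units; within the scatter). Compound 3 `COc1ccc(-c2noc(-c3cc4ccccc4n3C)n2)cc1` returns only a limit in this assay, > 50000 nM, which is a limit and not a number; that is the limit of > 50000 nM in this assay, at which 1 of the 3 values shown sits. The step to it is an at least 1.8-fold higher number from compound 2 to compound 3 (0.25 log units; that floor lies within the scatter).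

Compound 4 `COc1ccc(-c2noc(-c3cc4cc(Cl)ccc4[nH]3)n2)cc1` differs from compound 2 by chloro in place of hydrogen on an aromatic carbon. Neither measured step touches this place: the step of a 2.0-fold higher number from compound 1 to compound 2 (0.30 log units; within the scatter) exchanges chloro and methoxy on another aromatic carbon, and the step of an at least 1.8-fold higher number from compound 2 to compound 3 (0.25 log units; that floor lies within the scatter) alters the aromatic nitrogen. Both stay within the scatter, so no shift beyond the scatter is expected in this assay here either; the chloro of compound 1 is the only related point, and it gives no guide for a chloro at this place.

For compound 4 the value expected in this assay is 22000 nM, between 6000 nM and 55000 nM. For compound 4 this means an expected 1.3-fold lower number from compound 2 to compound 4 (0.10 log units; within the scatter).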

Compound 4, half-maximal inhibitory concentration: 9600 nM
Compound 4: the middle estimate sits 2.3-fold (0.36 log units) above what was measured; the measured number falls inside the stated range.
By their numbers in this assay, from the lowest: compounds 4, 1 and 2 (each within the scatter of the next, the first and the last beyond it). At a limit, above all of these: compound 3.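

In this assay a chloro on an aromatic carbon of the six-membered ring of the fused system gives a 2.9-fold lower number from compound 2 to compound 4 (0.46 log units; beyond the scatter). Among the compounds shown here, this is the first step printed as beyond the scatter, though a modest one, so this position responds to substitution in a way that the earlier steps, at another aromatic carbon and at the aromatic nitrogen, did not show. The change adds one heavy atom with no hydrogen-bond donor or acceptor, and nothing shown bears on the cause of the step.

Going by these compounds, whether the lower number is particular to chloro remains open, as an amine, a carboxylic acid or a longer chain at this position would test. Also open, on these data alone, is whether the step holds on the background of compound 1 or compound 3.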